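Three anilides at the assay limit, a fourth untested

A few compounds are considered here, and "the series" means these few. Any claim that something is new, unique, unknown or untested is made for them only; others in the source may bear on it.

Measured so far:
compound 1 `O=C(Nc1ccc(Cl)c(-c2nnc3c(Cl)cccn23)c1)c1cccnc1`, > 100000 nM
compound 2 `Cc1cc(Cl)ccc1C(=O)Nc1ccc(Cl)c(-c2nnc3c(Cl)cccn23)c1`, > 100000 nM
compound 3 `CS(=O)(=O)c1ccc(C(=O)Nc2ccc(Cl)c(-c3nnc4c(Cl)cccn34)c2)c(Cl)c1`, > 100000 nM

Compound 1 was tested in a functional assay on MCF7 cells (Homo sapiens) for antiproliferative activity, read by MTT assay, with a stated time of 72 h (on this read-out higher numbers stand for weaker inhibition and lower numbers for stronger inhibition), and gives > 100000 nM, a limit of the assay rather than a number. Compound 2 likewise gives only a limit, > 100000 nM. Compound 3 gives the limit > 100000 nM as well. Within the data shown here, the one single-point step among them, a step that the two limits leave unreadable from compound 1 to compound 2, cannot be read, since both ends sit at the limit. Among the measured compounds shown here, the only evidence the set offers is the limit of > 100000 nM in this assay, at which 3 of the 3 values shown sit.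

Compound 4 `O=C(Nc1ccc(Cl)c(-c2nnc3c(Cl)cccn23)c1)c1c(F)cccc1Cl` has not been measured. It differs from compound 1 by 2-chloro-6-fluorophenyl in place of pyridin-3-yl on a carbonyl carbon. For the measured compounds named here, no measured step bears on this change with a readable size, and none of the three measured compounds falls below the limit. From that the author expects compound 4 to show no step beyond the scatter, with a step that the limit leaves unreadable from compound 1 to compound 4, and most likely another limit rather than a number. The estimate for compound 4 is therefore 150000 nM, between 50000 nM and 500000 nM.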

Compound 4, half-maximal inhibitory concentration: > 100000 nM
Compound 4 was reported as a limit; the forecaster's own chance of this, stated with the estimate: 80%; the middle value does not contradict the limit.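

In this assay compound 4 gives > 100000 nM as a limit of the assay and not a number. The steps from compound 1 and from compound 2 to compound 4 therefore cannot be read. The compounds shown leave open whether any anilide on the shared core gives a readable value, and all they offer is this: the limit of > 100000 nM in this assay, at which 4 of the 4 values shown sit.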